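The source may hold more compounds than are shown below. What is called first, only, known or untested is meant among the compounds shown, and "the series" means these compounds.

Three esters were compared in a functional assay on a cell-free system (Platelet, plasma, Oryctolagus cuniculus) for inhibition, with a stated time of 5 min, at 37 degrees C; a lower number here means a stronger inhibitor, a higher number a weaker inhibitor. Compound 1 `Cc1nc(C)c(C(=O)Oc2ccccc2/C=C/C(=O)O)nc1C` gives 9600 nM in this assay. Compound 2 `COc1ccc(/C=C/C(=O)O)c(OC(=O)c2nc(C)c(C)nc2C)c1` gives 134000 nM in this assay, and compound 3 `COc1ccc(/C=C/C(=O)O)cc1OC(=O)c1nc(C)c(C)nc1C` gives 41800 nM in this assay. Compound 2 and compound 1 differ in a single place: hydrogen in place of methoxy on an aromatic carbon. That change made a 14-fold lower number from compound 2 to compound 1 (1.14 log units; beyond the scatter). Compound 3 is built from the same atoms as compound 2, joined differently; how the two cores differ is not broken down here. In this assay compound 3 stands between the other two, with a higher number than compound 1 and a lower number than compound 2.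

Compound 4 `Cc1nc(C)c(C(=O)Oc2cccc(/C=C/C(=O)O)c2)nc1C` has not yet been measured in this assay. It differs from compound 3 in one place: hydrogen in place of methoxy on an aromatic carbon. For the measured compounds named here, this is the same kind of change as the one from compound 2 to compound 1, but not the same: in compound 2 the methoxy that leaves is meta to a large group, whereas in compound 3 it is ortho to a large group; in both cases it is para to a 2-carboxyethenyl group. Going by the values given here, only one measured step of this kind exists, so any expectation rests on it alone. Compound 4 is expected to show a lower number than compound 3, the step being estimated at a 5.2-fold lower number from compound 3 to compound 4 (0.72 log units; beyond the scatter), because the like change gave a 14-fold lower number from compound 2 to compound 1 (1.14 log units; beyond the scatter), though the differing surroundings of the place leave this less certain. Compound 4 is therefore estimated at 8000 nM in this assay, with a range from 2500 nM to 30000 nM.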

Compound 4, half-maximal inhibitory concentration: 26400 nM
For compound 4 the middle estimate is 3.3-fold (0.52 log units) below the measured one; low and high end bracket the measured number.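

On the core of compound 3, hydrogen in place of methoxy on an aromatic carbon gives a 1.6-fold lower number from compound 3 to compound 4 (0.20 log units; within the scatter), so in this assay this pair shows no separable difference, whereas the same change on the core of compound 2 gave a clear step. The size of the step therefore does not carry over from one core to the other in this series, and the earlier step alone would not have been a safe guide to the later one: the same change on two cores in this assay, a 14-fold lower number (1.14 log units; beyond the scatter) from compound 2 to compound 1 and a 1.6-fold lower number (0.20 log units; within the scatter) from compound 3 to compound 4, 8.8-fold (0.95 log units) apart, beyond the scatter of two such steps

These two pairs do not show what sets the size of the step, since the cores differ in how their groups are arranged and two steps cannot separate one such feature from another, and they say nothing about how the change would behave on any further core.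

The compounds shown leave open whether a hydroxyl, a chlorine or an amine at the same place would behave like the hydrogen or like the methoxy on each core. They also leave open whether the contrast between the two cores would persist if an amide took the place of the ester or a longer chain took the place of the 2-carboxyethenyl group.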